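The compounds below may be only part of what the source reports. "The series", "measured", "known", "first", "only" and "open" are said of these compounds alone.

Measured so far:
compound 1 `Nc1nn(C(=O)Nc2ccc(Cc3ccccc3)cc2)c2ccccc12`, which in a functional assay on 786-0 cells (Homo sapiens) for antiproliferative activity, read by sulforhodamine B assay, with a stated time of 48 h (on this read-out higher numbers stand for weaker inhibition of growth and lower numbers for stronger inhibition of growth), gives 3760 nM
compound 2 `Nc1nn(C(=O)Nc2ccc(Cc3ccccc3)cc2)c2ccc(Cl)cc12`, which in this assay gives 3920 nM

These two compounds share a core and differ only where compound 2 carries a chloro group on an aromatic carbon in place of hydrogen. That replacement gave a 1.0-fold higher number from compound 1 to compound 2 (0.02 log units; within the scatter), so compound 2 stands with the higher of the two numbers, but its nearest neighbour, compound 1, is so close that no order between them can be read off.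

The next compound, compound 3 `Nc1ccc2c(c1)c(N)nn2C(=O)Nc1ccc(Cc2ccccc2)cc1`, keeps this scaffold and changes the same site once more: amino in place of chloro on an aromatic carbon. Going by the values given here, only one measured step bears on this position, the one from compound 1 to compound 2, and it was within the scatter. A small halogen at this site left the number where it was; the data hold nothing that tells how an amino group at the same place will behave. Without a step pointing in either direction, the expectation for compound 3 in this assay is a step of a 1.0-fold lower number from compound 2 to compound 3 (0.01 log units; within the scatter), that is, no movement beyond the scatter. Compound 3 is therefore estimated at 3800 nM, within a range from 1500 nM to 9500 nM.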

Compound 3, concentration for 50% growth inhibition: 12400 nM
For compound 3 the middle estimate is 3.3-fold (0.51 log units) below the measured one; the measured number lies above the stated range.
By their numbers in this assay, from the lowest: compounds 1 and 2 (each within the scatter of the next); then compound 3.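

In this assay, amino in place of chloro on this aromatic carbon gave a 3.2-fold higher number from compound 2 to compound 3 (0.50 log units; beyond the scatter), and amino in place of hydrogen at the same place gave a 3.3-fold higher number from compound 1 to compound 3 (0.52 log units; beyond the scatter). The earlier pair suggested that this position might make little difference, since hydrogen and chloro could not be told apart within the scatter, but compound 3 shows that the group here can change the result: amino goes with weaker inhibition of growth than either of the other two. What lies behind this difference cannot be said, as no measurement shown here bears on its cause.

The compounds shown leave open whether this shift belongs to amino alone or would also appear with other groups on this carbon, such as hydroxyl, methoxy or acetamido. They also leave open whether methylamino or dimethylamino, which keep a nitrogen attached at this place, would follow amino, and whether fluoro or bromo would instead stay with chloro and hydrogen.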